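A New Group on the Oxygen of Compound 1

The compounds below may be only part of what the source reports. "The series", "measured", "known", "first", "only" and "open" are said of these compounds alone.

Measured in an ADME assay on MDCK cells (Canis lupus familiaris) for permeability; on this read-out lower numbers stand for lower permeability and higher numbers for higher permeability:
- compound 1 `CCS(=O)(=O)Nc1ccc(Oc2ccc(C(F)(F)F)cc2)c(-c2cn(C)c(=O)c3[nH]ccc23)c1`: 11 10^-6 cm/s
- compound 2 `Cn1cc(-c2cc(NS(C)(=O)=O)ccc2OC2CCC(F)(F)CC2)c2cc[nH]c2c1=O`: 12 10^-6 cm/s

In this assay, compound 1 at 11 10^-6 cm/s and compound 2 at 12 10^-6 cm/s lie within the scatter of each other, so the two cannot be ranked. Compound 3 `CCS(=O)(=O)Nc1ccc(OC2CCC(N(C)C)CC2)c(-c2cn(C)c(=O)c3[nH]ccc23)c1` has not yet been measured. It keeps the core of compound 1 but carries 4-(dimethylamino)cyclohexyl in place of 4-(trifluoromethyl)phenyl on an oxygen on an aromatic ring. Among the measured compounds shown here, no measured pair isolates this change, so the expectation rests on the structural difference alone and remains uncertain. A moderate move towards a lower number, beyond the scatter, is expected in this assay. The estimated step is a 2.8-fold lower number from compound 1 to compound 3 (0.44 log units; beyond the scatter). For compound 3 the estimated value is 4 10^-6 cm/s, with an expected range of 1.5 10^-6 cm/s to 10 10^-6 cm/s.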

Compound 3, apparent permeability: 2.7 10^-6 cm/s
Compound 3: middle estimate off by 1.5-fold (0.17 log units), on the high side, within the range that was stated.
By their numbers in this assay, from the lowest: compound 3; then compounds 1 and 2 (each within the scatter of the next).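

Putting 4-(dimethylamino)cyclohexyl in place of 4-(trifluoromethyl)phenyl on an oxygen on an aromatic ring gives a 4.1-fold lower number from compound 1 to compound 3 (0.61 log units; beyond the scatter) in this assay, so this read-out responds to the group at this place, which compounds that differ in more than one place could not show. The change replaces an aromatic ring with a non-aromatic one and also exchanges fluorine for nitrogen, so this single step cannot be assigned to either difference. Nothing measured here accounts for the step.

As far as these compounds go, whether the ring or the nitrogen carries the step stays open, and plain cyclohexyl or 4-(dimethylamino)phenyl on the same oxygen would separate the two. From the compounds shown here alone, how a primary amine or a carboxylic acid in place of the dimethylamino group would read also remains unknown.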